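Methoxy addition on the benzamide ring of the K562 series

The compounds below may be only part of what the source reports. "The series", "measured", "known", "first", "only" and "open" are said of these compounds alone.

Measured so far:
Compound 1 `COc1ccc(C(=O)Nc2ccc(C)c(Nc3nccc(-c4cccnc4)n3)c2)cc1OCCCCn1ccnc1`: 10100 nM
Compound 2 `Cc1ccc(NC(=O)c2cccc(OCCCCn3ccnc3)c2)cc1Nc1nccc(-c2cccnc2)n1`: 74600 nM
Compound 3 `Cc1ccc(NC(=O)c2ccc(OCCCCn3ccnc3)cc2)cc1Nc1nccc(-c2cccnc2)n1`: 49900 nM

The three compounds share the same amide, methylphenyl and pyridinyl-pyrimidinyl-amine part and are read in a functional assay on K562 cells (Homo sapiens) for cytotoxicity, read by XTT assay, with a stated time of 24 h; on this read-out lower numbers stand for stronger inhibition and higher numbers for weaker inhibition. Compound 2 and compound 3 carry the same atoms joined differently; the difference between their cores is not broken down here, and their values in this assay lie within the scatter of each other. From compound 2 to compound 1 the change is methoxy in place of hydrogen on an aromatic carbon, and it gives a 7.4-fold lower number from compound 2 to compound 1 (0.87 log units; beyond the scatter).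

Compound 4 `COc1cc(C(=O)Nc2ccc(C)c(Nc3nccc(-c4cccnc4)n3)c2)ccc1OCCCCn1ccnc1` is not yet measured. From compound 3 to compound 4 the change is methoxy in place of hydrogen on an aromatic carbon. The two places are not the same word for word: in compound 1 the methoxy stands para to a large group, in compound 4 meta to it, so this is the same kind of change, not the same change.

Going by the values given here, the expectation for compound 4 rests on the one measured step, a 7.4-fold lower number from compound 2 to compound 1 (0.87 log units; beyond the scatter), and on compound 3 giving 49900 nM. The surroundings of the place differ, and a smaller step is expected, a 3.3-fold lower number from compound 3 to compound 4 (0.52 log units; beyond the scatter). Compound 4 is estimated at 15000 nM in this assay, within 6000 nM to 40000 nM.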

Compound 4, half-maximal inhibitory concentration: 29500 nM
Estimate against measurement, compound 4: 2.0-fold (0.29 log units) below, within the range that was stated.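

Methoxy in place of hydrogen on an aromatic carbon does not carry over at a fixed size in this assay: the same change on two cores in this assay, a 7.4-fold lower number (0.87 log units; beyond the scatter) from compound 2 to compound 1 and a 1.7-fold lower number (0.23 log units; within the scatter) from compound 3 to compound 4, 4.4-fold (0.64 log units) apart, beyond the scatter of two such steps. On the core of compound 3, with the methoxy ortho to a 4-(1H-imidazol-1-yl)butoxy group and meta to a large group, the change gives a 1.7-fold lower number from compound 3 to compound 4 (0.23 log units; within the scatter), so no effect can be claimed on this core. Going by these compounds alone, with only two pairs, and with the methoxy in a different place in each, the data do not show whether the core or the place accounts for the gap.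

On these data alone, whether an amine or a hydroxy group at these places would behave like methoxy remains open. So does the effect of a longer chain in place of the 4-(1H-imidazol-1-yl)butoxy group.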